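Swapping the nitrile for an alkyne in a cathepsin S inhibitor

A few compounds are considered here, and "the series" means these few. Any claim that something is new, unique, unknown or untested is made for them only; others in the source may bear on it.

Measured compounds and their values in an assay for inhibition of cathepsin S (Homo sapiens); a higher number here means a weaker inhibitor, a lower number a stronger inhibitor:
- compound 1, `CC(C)C[C@H](NC(=O)N1CCOCC1)C(=O)N[C@H](C#N)CCc1ccccc1`: 47 nM
- compound 2, `CC(C)C[C@H](NC(=O)N1CCOCC1)C(=O)N[C@H](C)CCc1ccccc1`: > 339000 nM, which is a limit of the assay, not a number
- compound 3, `CC(C)C[C@H](NC(=O)N1CCOCC1)C(=O)NCC#N`: 124 nM

Compound 3 has the highest of the two numbers shown; its nearest neighbour is compound 1, and the step of a 2.6-fold higher number from compound 1 to compound 3 (0.42 log units; beyond the scatter) goes with hydrogen in place of phenethyl. Compound 2 reports only a limit, (the limit of > 339000 nM in this assay, at which 1 of the 3 values shown sits), and no number.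

The unmeasured compound 4, `C#CCNC(=O)[C@H](CC(C)C)NC(=O)N1CCOCC1`, differs from compound 3 by ethynyl in place of cyano on a saturated chain carbon bound to an amide-type nitrogen. The measured step that bears on this is an at least 7200-fold higher number from compound 1 to compound 2 (3.85 log units; beyond the scatter), where the cyano also left, there replaced by methyl, and the loss was large. Since the cyano leaves again in compound 4, a large rise in the number in this assay is expected, a 1200-fold higher number from compound 3 to compound 4 (3.08 log units; beyond the scatter). Compound 4 is therefore estimated at 150000 nM, within a range of 10000 nM to 1000000 nM, with a good chance that only a limit is reported.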

Compound 4, half-maximal inhibitory concentration: 97000 nM
The estimate for compound 4 lay 1.5-fold (0.19 log units) above the measured number; the range from low to high includes it.
By their numbers in this assay, from the lowest: compound 1; then compound 3; then compound 4. At a limit, above all of these: compound 2.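

In this assay the swap gives a 780-fold higher number from compound 3 to compound 4 (2.89 log units; beyond the scatter), so replacing the cyano on this carbon now has a size, with a real number at both ends. The earlier replacement of the cyano, by methyl in compound 2, ended only in a limit: the limit of > 339000 nM in this assay, at which 1 of the 4 values shown sits. Ethynyl keeps the triple bond and the heavy-atom count of cyano, exchanging only a nitrogen for a carbon and losing the one hydrogen-bond acceptor, so a triple bond on this carbon does not by itself keep the number low.

As far as these compounds go, whether an aldehyde or a ketone could stand in for the cyano at this position remains open. Also open, from the compounds shown here alone, is how large the step would be with the phenethyl of compound 1 in place, as compound 4 carries hydrogen there.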